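Swapping the Aminobenzoyl Amide for an Isopropyl Carbamate

The source may report more compounds than this note shows. Statements on the series, on what has been measured and on what is new or still open speak of the compounds shown alone.

In a functional assay on HCT-116 cells (Homo sapiens) for cytotoxicity, read by MTT assay (on this read-out lower numbers stand for stronger inhibition and higher numbers for weaker inhibition), compound 1 `CCc1cc(S(=O)(=O)N2C[C@H](c3ccccc3)NC2=O)ccc1NC(=O)c1ccc(N)cc1` gives 460 nM, the lowest of the two numbers recorded here. Compound 2 `CCOC(=O)Nc1ccc(S(=O)(=O)N2C(=O)N[C@@H](c3ccccc3)C2C)cc1Cl` gives the higher number, 5500 nM, but its core also differs, so it offers no clean comparison. Compound 3 `Cc1cc(S(=O)(=O)N2C(=O)N[C@@H](c3ccccc3)C2C)ccc1NC(=O)c1ccc([N+](=O)[O-])cc1` reaches only the limit of this assay, > 10000 nM; this is the limit of > 10000 nM in this assay, at which 1 of the 3 values shown sits. Compound 4 `CCc1cc(S(=O)(=O)N2C[C@H](c3ccccc3)NC2=O)ccc1NC(=O)OC(C)C` has not yet been measured; it differs from compound 1 by isopropoxy in place of 4-aminophenyl on a carbonyl carbon. No single-change step between measured compounds is available, so the expectation rests on the spread of the numbers shown. The step is expected to weaken inhibition, a 6.5-fold higher number from compound 1 to compound 4 (0.81 log units; beyond the scatter). Compound 4 is estimated at 3000 nM, with a range from 800 nM to 12000 nM.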

Compound 4, half-maximal inhibitory concentration: 60 nM
The estimate for compound 4 lay 50-fold (1.70 log units) above the measured number; measured number below the stated range.
By their numbers in this assay, from the lowest: compound 4; then compound 1; then compound 2. At a limit, above all of these: compound 3.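

In this assay, the carbonyl carbon on the amide-type nitrogen does not need 4-aminophenyl: isopropoxy there gives a 7.7-fold lower number from compound 1 to compound 4 (0.88 log units; beyond the scatter) on the shared core. Within the data shown here, a group with no ring and no hydrogen-bond donors is therefore accepted at this place, something the earlier compounds, which differ in more than one place, could not show. Nothing measured here accounts for the direction of this step.

The compounds shown leave open how much the size of the alkoxy group matters. A tert-butoxy or benzyloxy group on the same carbonyl would test this.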